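From chloro to trifluoromethyl on the benzyl group

A few compounds are considered here, and "the series" means these few. Any claim that something is new, unique, unknown or untested is made for them only; others in the source may bear on it.

Measured in a functional assay on B16 cells (Mus musculus) for antiproliferative activity, read by MTT assay, with a stated time of 24 h; a higher number here means a weaker inhibitor, a lower number a stronger inhibitor:
- compound 1 `C#CCOc1ccc2c(=O)c(-c3cc(OC)c(OC)cc3OC)coc2c1`: 4500 nM
- compound 2 `COc1cc(OC)c(-c2coc3cc(OCc4ccccc4C)ccc3c2=O)cc1OC`: 2150 nM
- compound 3 `COc1cc(OC)c(-c2coc3cc(OCc4ccc(Cl)cc4)ccc3c2=O)cc1OC`: 2400 nM

Compound 3 cannot be separated from the other two, with a 1.1-fold higher number from compound 2 to compound 3 (0.05 log units; within the scatter) and a 1.9-fold lower number from compound 1 to compound 3 (0.27 log units; within the scatter). Compound 4 `COc1cc(OC)c(-c2coc3cc(OCc4ccc(C(F)(F)F)cc4)ccc3c2=O)cc1OC` carries trifluoromethyl in place of chloro, on an aromatic carbon para to a large group: trifluoromethyl in place of chloro on an aromatic carbon. Among the compounds with values here, no measured step makes this exact swap. The closest is the exchange of one substituted phenyl for another, a 1.1-fold higher number from compound 2 to compound 3 (0.05 log units; within the scatter). Within the data shown here, the only step beyond the scatter, a 2.1-fold lower number from compound 1 to compound 2 (0.32 log units; beyond the scatter), replaces ethynyl, a different kind of change. The expected step is a 1.0-fold lower number from compound 3 to compound 4 (0.02 log units; within the scatter), so nothing beyond the scatter is anticipated in this assay. Compound 4 is estimated at 2300 nM, with an expected range from 1200 nM to 4500 nM.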

Compound 4, half-maximal inhibitory concentration: 5400 nM
Compound 4: middle estimate off by 2.3-fold (0.37 log units), on the low side, outside the stated range (above it).
By their numbers in this assay, from the lowest: compounds 2, 3, 1 and 4 (each within the scatter of the next, the first and the last beyond it).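

In this assay, this aromatic carbon of the benzyl group proves sensitive to its substituent: trifluoromethyl in place of chloro gives a 2.3-fold higher number from compound 3 to compound 4 (0.35 log units; beyond the scatter), a step beyond the scatter that no exchange among the earlier benzyl groups produced. The trifluoromethyl compound also separates from the 2-methylphenyl one, with a 2.5-fold higher number from compound 2 to compound 4 (0.40 log units; beyond the scatter), yet it stays within the scatter of ethynyl, with a 1.2-fold higher number from compound 1 to compound 4 (0.08 log units; within the scatter), so adding a substituted phenyl does not by itself lower the number. Nothing available explains this step.

As far as these compounds go, whether a nitrile or an amine on this same aromatic carbon would sit nearer chloro or trifluoromethyl remains open.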